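Chloro at the ring nitrogen in two related cores

The source may hold more compounds than are shown below. What is called first, only, known or untested is meant among the compounds shown, and "the series" means these compounds.

Compound 1 `Fc1cccc(F)c1C#Cc1cncc2ccccc12` gives 16.5% in a functional assay on LS174T cells (Homo sapiens) for inhibition, with a stated time of 4 days, tested at 1 uM; on this read-out higher numbers stand for a stronger effect at the one concentration tested and lower numbers for a weaker effect. Compound 2 `Fc1cccc(F)c1C#Cc1cnc(Cl)c2ccccc12` carries the change chloro in place of hydrogen on an aromatic carbon and in this assay compound 2 gives 48.1%, a step of a number 31.6 percentage points higher from compound 1 to compound 2 (beyond the scatter). Compound 3 `Fc1cccc(F)c1C#Cc1cnc2ccccc2c1` has the same atoms as compound 1, joined differently; the difference between the two cores is not broken down here. In this assay compound 3 gives 41.7%, which sits within the scatter of compound 2 and beyond it relative to compound 1.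

Compound 4 `Fc1cccc(F)c1C#Cc1cc2ccccc2nc1Cl` has not yet been measured. It differs from compound 3 by chloro in place of hydrogen on an aromatic carbon. This is the same kind of change as from compound 1 to compound 2, though not the same: in compound 2 the chloro stands ortho to a fused ring and para to a large group, whereas in compound 4 it stands ortho to a large group and para to a fused ring. Compound 4 is expected to reach about 60%, estimated between 40% and 80%. The expected step of a number 18.3 percentage points higher from compound 3 to compound 4 (beyond the scatter) is estimated smaller than the earlier one because compound 3 already gives 41.7% and the place around the chloro is not identical.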

Compound 4, a percentage reported as inhibition, at one concentration (the size of the read-out at that concentration, not a potency): 28.4%
Compound 4: middle estimate off by 31.6 percentage points, on the high side; measured number outside the range, below it.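

In this assay, the same replacement of hydrogen by chloro gives a step of a number 13.3 percentage points lower from compound 3 to compound 4 (beyond the scatter), so the change does not keep its direction from one core to the other: the same change on two cores in this assay, a number 31.6 percentage points higher (beyond the scatter) from compound 1 to compound 2 and a number 13.3 percentage points lower (beyond the scatter) from compound 3 to compound 4, 44.9 percentage points apart, beyond the scatter of two such steps The result shows that the step seen on the core of compound 1 cannot be carried over to the core of compound 3 in this series, not even as a guide to its sign. Going by these compounds alone, it does not show whether the core itself or the place of the chloro accounts for the gap, since the chloro in compound 4 stands next to the ring nitrogen and ortho to a large group, a different place from the one it holds in compound 2, and two pairs cannot separate these factors.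

The compounds shown carry only hydrogen or chloro at these places, so it remains open how a methoxy group or an amine there would behave on either core. As far as these compounds go, it also remains open whether chloro at other places on these cores would raise or lower the read-out.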